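Taking one hydroxy off compound 2

The source may report more compounds than this note shows. Statements on the series, on what has been measured and on what is new or still open speak of the compounds shown alone.

In a functional assay on NCI-H226 cells (Homo sapiens) for inhibition (a lower number here means a stronger inhibitor of growth, a higher number a weaker inhibitor of growth), compound 2 `NS(=O)(=O)c1ccc(/C=C/c2ccc(O)c(O)c2)cc1` gives 14000 nM, the highest number of the three measured. That value lies within the scatter of compound 1 `COc1cc(/C=C/c2ccc(S(N)(=O)=O)cc2)cc(OC)c1` at 12300 nM, so the two cannot be ranked. Compound 3 `COc1cccc(/C=C/c2ccc(S(N)(=O)=O)cc2)c1` stands clearly lower at 2910 nM.

The next compound is compound 4 `NS(=O)(=O)c1ccc(/C=C/c2ccc(O)cc2)cc1`, which has hydrogen in place of hydroxy on an aromatic carbon. The group removed is ortho to a hydroxy group and meta to a large group.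

Among the compounds with values here, only one measured step is close to this change: a 4.2-fold lower number from compound 1 to compound 3 (0.63 log units; beyond the scatter). It also puts hydrogen on an aromatic carbon, but in place of methoxy, and it is modest in size and beyond the scatter. Within the data shown here, no measured step removes a hydroxy, so the transfer is uncertain and no change at all remains possible.

A similar move towards a lower number in this assay is expected, slightly smaller than that precedent: a 3.1-fold lower number from compound 2 to compound 4 (0.49 log units; beyond the scatter). The estimate for compound 4 is 4500 nM, with an expected range of 1700 nM to 13000 nM.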

Compound 4, concentration for 50% growth inhibition: 11100 nM
Compound 4: middle estimate off by 2.5-fold (0.39 log units), on the low side, and the stated range covers the measured number.
By their numbers in this assay, from the lowest: compound 3; then compounds 4, 1 and 2 (each within the scatter of the next).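

In this assay the hydroxy ortho to a hydroxy group and meta to a large group can be replaced by hydrogen with no readable effect on growth inhibition: the change gives a 1.3-fold lower number from compound 2 to compound 4 (0.10 log units; within the scatter) and so compound 2 and compound 4 cannot be ranked. Within the data shown here, the only earlier step that puts hydrogen on an aromatic carbon, a 4.2-fold lower number from compound 1 to compound 3 (0.63 log units; beyond the scatter) removes a methoxy from a different compound, and its size does not carry over to this hydroxy at this position. No measurement at hand offers an explanation for this difference between the two steps.

Open, going by these compounds, is whether the remaining hydroxy of compound 4 can also be replaced without a shift in the number. Also open, on these data alone, is what an amine or a carboxylic acid on this same aromatic carbon would do.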